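Chloro in place of hydrogen on a pyridyl group

The compounds below may be only part of what the source reports. "The series", "measured", "known", "first", "only" and "open" are said of these compounds alone.

Compound 1 `Fc1cccc(NCc2ccc(CNc3cccc(F)n3)cc2)n1` gives 55% in a functional assay on MDA-MB-231 cells for antagonist activity at C-X-C chemokine receptor type 4 (Homo sapiens), tested at 10 nM; on this read-out higher numbers stand for a stronger effect at the one concentration tested and lower numbers for a weaker effect.
Compound 2 `Fc1ccc(NCc2ccc(CNc3ccc(F)cn3)cc2)nc1` gives 45% in this assay.
Compound 3 `c1ccc(NCc2ccc(CNc3ncccn3)cc2)nc1` gives 58% in this assay.

All three share a core in which two aromatic amines hang from a central benzene through methylene links, and differ only in the aromatic groups at the ends. Compound 3 has the highest of the three numbers in this assay, yet its number lies within the usual scatter of that of compound 1, so the two cannot be told apart; only compound 2 sits beyond the scatter below it.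

Compound 4 `Clc1ccc(NCc2ccc(CNc3ncccn3)cc2)nc1` has not yet been measured. It differs from compound 3 by a single change: chloro in place of hydrogen on an aromatic carbon. Among the measured compounds shown here, no pair of measured compounds shows this kind of change, so nothing here tells how a chloro in this place alters the read-out. A step no larger than the scatter is therefore expected from compound 3 to compound 4, no change at the digits printed from compound 3 to compound 4 (within the scatter), in either direction. For compound 4 the estimate in this assay is 58%, with a range from 40% to 76%.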

Compound 4, a percentage reported as inhibition, at one concentration (the size of the read-out at that concentration, not a potency): 82%
Compound 4: the middle estimate sits 24 percentage points below what was measured; measured number outside the range, above it.
By their numbers in this assay, from the lowest: compounds 2, 1 and 3 (each within the scatter of the next, the first and the last beyond it); then compound 4.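

Among the compounds shown here, replacing hydrogen with chloro, which turns pyridin-2-yl into 5-chloropyridin-2-yl, is the first single change that can be read here, and in this assay it gives a number 24 percentage points higher from compound 3 to compound 4 (beyond the scatter). This shows that the read-out is sensitive to this aromatic carbon, para to a large group and two atoms from the ring nitrogen, and that one chlorine atom here can raise the effect at the one concentration tested rather than lower it. Nothing measured here explains the rise.

As far as these compounds go, it remains open whether the gain is specific to chloro or would also appear with a bromo, a methyl or a methoxy group on the same carbon. From the compounds shown here alone, it is also open whether the same chloro would raise the number on a different group at the other end of the shared core.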